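Dimethylamino for Chloro on a Dienone Aryl Ring

The compounds below may be only part of what the source reports. "The series", "measured", "known", "first", "only" and "open" are said of these compounds alone.

Compound 1, `O=C1C=CCC/C1=C\C(Br)=C\c1ccccc1`: > 10000 nM
Compound 2, `O=C1C=CCC/C1=C\C=C\c1ccc(Cl)cc1`: 3500 nM
Compound 3, `COc1ccccc1/C=C/C=C1\CCC=CC1=O`: 2800 nM

Of the compounds shown here, three with a shared core have been measured in a functional assay on HCT-116 cells (Homo sapiens) for cytotoxicity, read by MTT assay, with a stated time of 72 h; on this read-out lower numbers stand for stronger inhibition and higher numbers for weaker inhibition. For compound 1 the result is a limit of the assay rather than a number, as the limit of > 10000 nM in this assay, at which 1 of the 3 values shown sits, records. Compound 2 and compound 3 supply the two numbers, and they lie within the scatter of each other. Compound 4 `CN(C)c1ccc(/C=C/C=C2\CCC=CC2=O)cc1` remains to be measured; it differs from compound 2 by dimethylamino in place of chloro on an aromatic carbon. Among the compounds with values here, no step between two measured compounds exists to calibrate this change, so the size of the step is unknown from the data; a modest move toward a lower number, near the edge of the scatter, is expected in this assay. Compound 4 is estimated at 2000 nM (range 700 nM to 6000 nM), which would mean an expected step of a 1.8-fold lower number from compound 2 to compound 4 (0.24 log units; within the scatter).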

Compound 4, half-maximal inhibitory concentration: 1200 nM
Compound 4: middle estimate off by 1.7-fold (0.22 log units), on the high side; the range from low to high includes it.
By their numbers in this assay, from the lowest: compound 4; then compounds 3 and 2 (each within the scatter of the next). At a limit, above all of these: compound 1.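

Within the data shown here, the exchange gives the first step that can be read: with dimethylamino in place of chloro on this aromatic carbon, para to a large group, this assay shows a 2.9-fold lower number from compound 2 to compound 4 (0.46 log units; beyond the scatter). The read-out at this position therefore responds to this change by more than the usual scatter. Nothing measured here accounts for the size of the step.

The compounds shown leave open how a primary amine or a carboxylic acid on the same aromatic carbon would read. They also leave open whether the same exchange would give a similar step on the bromo-bearing core of compound 1.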